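Trimming the Anilino Group from a Weak Urea

The compounds below may be only part of what the source reports. "The series", "measured", "known", "first", "only" and "open" are said of these compounds alone.

Compound 1 `CC1(C)CC(NC(=O)Nc2ccccc2)c2cc(Cl)ccc2O1`: 68000 nM
Compound 2 `CC1(C)CC(NC(=O)Nc2ccc(Cl)cc2)c2cc(F)ccc2O1`: 24000 nM
Compound 3 `CC1(C)CC(NC(=S)Nc2ccc([N+](=O)[O-])cc2)c2cc(Cl)ccc2O1`: 3000 nM

In a functional assay on U-373MG ATCC cells (Homo sapiens) for inhibition, read by MTT assay, with a stated time of 72 h (on this read-out higher numbers stand for weaker inhibition and lower numbers for stronger inhibition), compound 1 gives 68000 nM, the highest of the three numbers, which makes it the weakest inhibitor measured so far. Compound 2 reads 24000 nM and compound 3 reads 3000 nM, both clearly lower.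

Compound 4 `CC(=O)NC1CC(C)(C)Oc2ccc(Cl)cc21` has not yet been measured. It differs from compound 1 at a single place: methyl in place of anilino on a carbonyl carbon. In words, this is methyl in place of anilino on a carbonyl carbon. The change removes a six-membered aromatic ring of carbon only, and all three measured compounds carry such a ring. For the measured compounds named here, no measured pair shows this change, so any expectation is loose. A modest step in this assay towards weaker inhibition, meaning a higher number, seems most likely. The estimated step is a 2.2-fold higher number from compound 1 to compound 4 (0.34 log units; beyond the scatter). The estimate for compound 4 is 150000 nM, with an expected range of 50000 nM to 400000 nM.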

Compound 4, half-maximal inhibitory concentration: > 100000 nM
Compound 4 ended at the assay's limit; the forecaster's own chance of this, stated with the estimate: 35%; the middle value is on the limit's open side.
By their numbers in this assay, from the lowest: compound 3; then compound 2; then compound 1. At a limit, above all of these: compound 4.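

In this assay compound 4 gives > 100000 nM and that is a limit of the assay, not a number. On these data alone, putting methyl in place of anilino on the carbonyl carbon gives an at least 1.4-fold higher number from compound 1 to compound 4 (0.16 log units; that floor lies within the scatter) as a floor only, so the true size of this change stays unknown. Compound 4 is the first compound shown without a six-membered aromatic ring, and its reading gives no sign that methyl can stand in for anilino at this position, though the scale ends before any real comparison can be made: the limit of > 100000 nM in this assay, at which 1 of the 4 values shown sits.

The anilino group leaves as a whole, so its ring and its nitrogen cannot be told apart here. A cyclohexylamino group on the same carbonyl carbon would keep the nitrogen without the aromatic ring, and a phenyl group would keep the aromatic ring without the nitrogen.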